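The source may report more compounds than this note shows. Statements on the series, on what has been measured and on what is new or still open speak of the compounds shown alone.

Measured so far in an assay on microsomes from liver for inhibition of 3-hydroxy-3-methylglutaryl-coenzyme A reductase (Rattus norvegicus); on this read-out higher numbers stand for weaker inhibition and lower numbers for stronger inhibition:
- compound 1 `Cc1ccc(CNC(=O)c2nn(-c3ccc(F)cc3)c(CC[C@@H](O)C[C@@H](O)CC(=O)O)c2C(C)C)cc1`: 2.5 nM
- compound 2 `CC(C)c1c(C(=O)N2CCC[C@H](c3ccccc3)C2)nn(-c2ccc(F)cc2)c1CC[C@@H](O)C[C@@H](O)CC(=O)O`: 2.1 nM

For the measured compounds named here, compound 2 gives the lowest of the two numbers in this assay, and its only neighbour, compound 1, sits at a 1.2-fold lower number from compound 1 to compound 2 (0.08 log units; within the scatter). The two values therefore cannot be placed in any order; the amide-side exchange of a 3-phenylpiperidin-1-yl for a (4-methylbenzyl)amino left the read-out unchanged within the scatter.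

Compound 3 `CC(C)c1c(C(=O)N2CCC[C@H](N3CCC4C=CC=CC4C3)C2)nn(-c2ccc(F)cc2)c1CC[C@@H](O)C[C@@H](O)CC(=O)O` keeps the shared core of compound 2 and alters only the group on the saturated ring carbon: a group of 10 heavy atoms (9 carbon, 1 nitrogen; one six-membered non-aromatic ring of carbon only, one six-membered non-aromatic ring with 1 hetero atom) in place of a group of 6 heavy atoms (6 carbon; one six-membered aromatic ring of carbon only), on a saturated ring carbon.

Going by the values given here, only one measured step bears on this region, the one from compound 1 to compound 2, and it was within the scatter. Among the compounds with values here, no measured pair tests what a bulkier, nitrogen-containing replacement for the phenyl does at this position, so the single relevant step gives no direction. The prior expectation is a step near zero, with a wide range to allow for the larger group; the estimated step is a 1.7-fold higher number from compound 2 to compound 3 (0.22 log units; within the scatter).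

For compound 3 the estimate in this assay is 3.5 nM, with a range from 1.2 nM to 12 nM.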

Compound 3, half-maximal inhibitory concentration: 10 nM
The estimate for compound 3 lay 2.9-fold (0.46 log units) below the measured number; low and high end bracket the measured number.
By their numbers in this assay, from the lowest: compounds 2 and 1 (each within the scatter of the next); then compound 3.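

In this assay, for the compounds shown here, the exchange of phenyl for the group of 10 heavy atoms gives a 4.8-fold higher number from compound 2 to compound 3 (0.68 log units; beyond the scatter), the first step beyond the scatter, so the read-out does respond to what sits on this saturated ring carbon, two ring bonds from the ring nitrogen. The step is modest, and the larger group is still accommodated here, with compound 3 at 10 nM, but the exchange brings in more heavy atoms, a ring nitrogen, a second ring and the loss of the aromatic ring all at once, and this one pair cannot separate those changes. Nothing available explains the size or direction of this step.

The compounds shown leave open whether the higher number follows the ring nitrogen, the added ring or the non-aromatic character of the entering group. A piperidin-1-yl group or a cyclohexyl group on the same carbon would help separate these, while a benzyl group would show whether a phenyl ring set one atom further out holds the number of compound 2.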